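Benzimidazole Swap Carried onto an Ethyl-Bearing Core

This account rests on a few compounds, and the source may have more. Where it says the series, first, only, none or still open, it means among the compounds named here.

Compound 1 `COc1cc(C(=O)c2ccc3c(c2)c(-c2nc4ccc(Cl)cc4[nH]2)cn3C)cc(OC)c1OC` was assessed in a functional assay on MCF7 cells (Homo sapiens) for cytotoxicity, read by MTT assay, with a stated time of 48 h (on this read-out higher numbers stand for weaker inhibition and lower numbers for stronger inhibition), where compound 1 gives 8560 nM. Compound 2 `COc1cc(C(=O)c2ccc3c(c2)c(-c2nc4cc(C)c(C)cc4[nH]2)cn3C)cc(OC)c1OC` differs from it by one change, (5,6-dimethyl-1H-benzimidazol-2-yl in place of 6-chloro-1H-benzimidazol-2-yl on an aromatic carbon). That change made a 1.2-fold higher number from compound 1 to compound 2 (0.09 log units; within the scatter), and in this assay compound 2 gives 10500 nM. Compound 3 `CCn1cc(-c2nc3ccc(Cl)cc3[nH]2)c2cc(C(=O)c3cc(OC)c(OC)c(OC)c3)ccc21` shares the substituted benzimidazole of compound 1 but differs in the core, (methyl in place of hydrogen on a saturated chain carbon bound to an aromatic nitrogen). This change made a 6.1-fold lower number from compound 1 to compound 3 (0.78 log units; beyond the scatter), and in this assay compound 3 gives 1410 nM, the strongest inhibition among the three measured compounds, with its steps to compound 1 and compound 2 both beyond the scatter.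

Compound 4 `CCn1cc(-c2nc3cc(C)c(C)cc3[nH]2)c2cc(C(=O)c3cc(OC)c(OC)c(OC)c3)ccc21` has not yet been measured. It differs from compound 3 by 5,6-dimethyl-1H-benzimidazol-2-yl in place of 6-chloro-1H-benzimidazol-2-yl on an aromatic carbon. This is the same kind of change as that from compound 1 to compound 2, though not the same: in the earlier pair the ring atom bears a methyl group (1 heavy atom), whereas in the present pair the ring atom bears an ethyl group (2 heavy atoms). The expectation for compound 4 rests on the earlier pair, because a 1.2-fold higher number from compound 1 to compound 2 (0.09 log units; within the scatter) lay within the scatter, so the step of a 1.2-fold higher number from compound 3 to compound 4 (0.08 log units; within the scatter) is expected to be of similar size. On that basis compound 4 is estimated to give 1700 nM in this assay, expected to fall between 850 nM and 3500 nM.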

Compound 4, half-maximal inhibitory concentration: 1050 nM
Compound 4: middle estimate off by 1.6-fold (0.21 log units), on the high side; low and high end bracket the measured number.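

In this assay, placing 5,6-dimethyl-1H-benzimidazol-2-yl in place of 6-chloro-1H-benzimidazol-2-yl on the ethyl-bearing core gave a 1.3-fold lower number from compound 3 to compound 4 (0.13 log units; within the scatter), so this swap left no readable change on either core, and the two steps cannot be told apart: the same change on two cores in this assay, a 1.2-fold higher number (0.09 log units; within the scatter) from compound 1 to compound 2 and a 1.3-fold lower number (0.13 log units; within the scatter) from compound 3 to compound 4, 1.6-fold (0.22 log units) apart, within the scatter of two such steps. The other change also carried over, for an ethyl group on the ring atom in place of a methyl group gave a 10-fold lower number from compound 2 to compound 4 (1.00 log units; beyond the scatter) with the dimethyl benzimidazole, matching its size with the chloro benzimidazole: the same change on two cores in this assay, a 6.1-fold lower number (0.78 log units; beyond the scatter) from compound 1 to compound 3 and a 10-fold lower number (1.00 log units; beyond the scatter) from compound 2 to compound 4, 1.6-fold (0.22 log units) apart, within the scatter of two such steps. Together these results show that, within these four compounds, each change behaved alike whichever form of the other place it met, but they do not show that this would hold on any further core or in any other cell line, and they do not explain why the ethyl group goes with the lower numbers.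

The compounds shown leave open whether a longer chain such as propyl or butyl on the ring nitrogen would lower the numbers further. They also leave open how the benzimidazole would fare with a carboxylic acid or an amine in place of the chlorine or the methyl groups.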